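A few compounds are considered here, and "the series" means these few. Any claim that something is new, unique, unknown or untested is made for them only; others in the source may bear on it.

Compound 3, `Cc1ccc(S(=O)(=O)N2CCC(Br)=CC2CC(C)C)cc1`, stands lowest of the two numbers given in a functional assay on WiDr cells (Homo sapiens) for antiproliferative activity, read by sulforhodamine B assay, with a stated time of 48 h; a higher number here means a weaker inhibitor of growth, a lower number a stronger inhibitor of growth: compound 3 gives 16000 nM, while compound 1, `CCCCCCCC1C=C(Cl)CCN1S(=O)(=O)c1ccc(C)cc1`, gives 50000 nM, a higher number that lies beyond the usual scatter. Compound 2, `Cc1ccc(S(=O)(=O)N2CC=C(Br)CC2)cc1`, reaches only the limit of this assay at > 100000 nM. Compound 4, `CCCCCCCC1C=C(Br)CCN1S(=O)(=O)c1ccc(C)cc1`, is still to be measured; it differs from compound 3 by hexyl in place of isopropyl on a saturated chain carbon bound to a saturated ring carbon. For the measured compounds named here, the one measured step that touches this part of the molecule is an at least 6.2-fold lower number from compound 2 to compound 3 (0.79 log units; beyond the scatter), which shows that putting a chain on that ring carbon lowers the number well beyond the scatter. Compound 4, however, carries the same long chain as compound 1, and compound 1 with its value of 50000 nM gives a higher number than compound 3 does. The step from the shorter to the longer chain is therefore expected to raise the number, by a 2.5-fold higher number from compound 3 to compound 4 (0.40 log units; beyond the scatter). Compound 4 is estimated at 40000 nM, within a range from 15000 nM to 110000 nM.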

Compound 4, concentration for 50% growth inhibition: 40000 nM
The estimate for compound 4 equals the measured number at the digits printed; the range from low to high includes it.
By their numbers in this assay, from the lowest: compound 3; then compounds 4 and 1 (each within the scatter of the next). At a limit, above all of these: compound 2.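

In this assay, for the compounds shown here, hexyl in place of isopropyl on a saturated chain carbon bound to a saturated ring carbon gives a 2.5-fold higher number from compound 3 to compound 4 (0.40 log units; beyond the scatter) with bromo held fixed, the first comparison of two chains at this place, while a 1.3-fold lower number from compound 1 to compound 4 (0.10 log units; within the scatter) means that bromo in place of chloro on a double-bonded ring carbon does not separate this pair. The step of an at least 2.5-fold lower number from compound 2 to compound 4 (0.39 log units; beyond the scatter) leads from the compound without a chain to the one with the long chain, so even the long chain keeps a lower number than no chain at all. That step rests on compound 2, whose value is a limit and not a number: the limit of > 100000 nM in this assay, at which 1 of the 4 values shown sits.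

Going by these compounds, two chain lengths give no trend, so a butyl chain or a chain ending in an amine or a carboxylic acid remains open at this place. Whether bromo and chloro also match with the isobutyl chain stands open too.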